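This account rests on a few compounds, and the source may have more. Where it says the series, first, only, none or still open, it means among the compounds named here.

Compound 2, `Cc1nn(-c2ccccc2)cc1/C=N/Nc1nc(Nc2ccccc2)nc(Nc2ccc(S(N)(=O)=O)cc2)n1`, gives 2440 nM in a functional assay on NCI-H322M cells (Homo sapiens) for inhibition, read by sulforhodamine B assay, with a stated time of 48 h; on this read-out higher numbers stand for weaker inhibition of growth and lower numbers for stronger inhibition of growth. Among the compounds with values here, its only companion is compound 1, `NS(=O)(=O)c1ccc(Nc2nc(N/N=C/c3ccc(C(F)(F)F)cc3)nc(Nc3ccccc3)n2)cc1`, which in this assay gives 3310 nM; the two numbers lie within the scatter of each other, so neither can be set apart from the other. Compound 3, `NS(=O)(=O)c1ccc(Nc2nc(N/N=C/c3ccccn3)nc(Nc3ccccc3)n2)cc1`, differs from compound 2 in one place: pyridin-2-yl in place of 3-methyl-1-phenyl-1H-pyrazol-4-yl on a carbon with a double bond to nitrogen. Within the data shown here, the single measured step that touches this position is the change from compound 1 to compound 2, and it gave a 1.4-fold lower number from compound 1 to compound 2 (0.13 log units; within the scatter), so swapping the group on that carbon has so far not moved the number beyond the scatter. On that basis the expectation for compound 3 is a step of a 1.1-fold higher number from compound 2 to compound 3 (0.06 log units; within the scatter) in this assay, that is, no change beyond the scatter. The estimated value for compound 3 is therefore 2800 nM, with a range from 1200 nM to 6500 nM.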

Compound 3, concentration for 50% growth inhibition: 400 nM
The estimate for compound 3 lay 7.0-fold (0.85 log units) above the measured number; the measured number lies below the stated range.
By their numbers in this assay, from the lowest: compound 3; then compounds 2 and 1 (each within the scatter of the next).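

Until now, changing the group on the carbon with a double bond to nitrogen had not moved the number in this assay beyond the scatter, so this position could have seemed insensitive to what it carries. Pyridin-2-yl shows otherwise: in place of 3-methyl-1-phenyl-1H-pyrazol-4-yl it gives a 6.1-fold lower number from compound 2 to compound 3 (0.79 log units; beyond the scatter), and in place of 4-(trifluoromethyl)phenyl it gives an 8.3-fold lower number from compound 1 to compound 3 (0.92 log units; beyond the scatter). No measurement shown here explains this gain in growth inhibition.

The compounds shown leave open whether the gain depends on the ring nitrogen of pyridin-2-yl, on where that nitrogen sits in the ring, or on other features of the group. A plain phenyl group and pyridin-4-yl on the same carbon would help to separate these possibilities.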